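Contracting the Fused Ring of Compound 2

A few compounds are considered here, and "the series" means these few. Any claim that something is new, unique, unknown or untested is made for them only; others in the source may bear on it.

Within the data shown here, in an ADME assay on microsomes from liver (Homo sapiens) for metabolic stability (on this read-out higher numbers stand for fast clearance and lower numbers for slow clearance), compound 1 `CC(=O)N[C@@H]1CCC[C@H](C(=O)Nc2cc(-c3cnn4c3CCCC4)c(Cl)cn2)C1` gives 17 mL.min-1.g-1 and compound 2 `CC(=O)N[C@@H]1CCC[C@H](C(=O)Nc2cc(-c3cnc4n3CCCC4)c(Cl)cn2)C1` gives 16 mL.min-1.g-1, so compound 2 stands level with its only neighbour. That measured step, a 1.1-fold lower number from compound 1 to compound 2 (0.03 log units; within the scatter), lies within the scatter and exchanges groups of equal size. Compound 3 `CC(=O)N[C@@H]1CCC[C@H](C(=O)Nc2cc(-c3cnc4n3CCC4)c(Cl)cn2)C1` makes one change: a group of 8 heavy atoms (6 carbon, 2 nitrogen; one five-membered non-aromatic ring with 1 hetero atom, one five-membered aromatic ring with 2 hetero atoms) in place of a group of 9 heavy atoms (7 carbon, 2 nitrogen; one five-membered aromatic ring with 2 hetero atoms, one six-membered non-aromatic ring with 1 hetero atom), on an aromatic carbon. Among the measured compounds shown here, no measured step shrinks the group in this way, so the evidence is thin and no shift beyond the scatter is expected. The expected step is small, a 1.1-fold lower number from compound 2 to compound 3 (0.06 log units; within the scatter). Compound 3 is estimated at 14 mL.min-1.g-1, with an expected range of 7 mL.min-1.g-1 to 28 mL.min-1.g-1.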

Compound 3, intrinsic clearance in microsomes: 9.7 mL.min-1.g-1
Compound 3: the middle estimate sits 1.4-fold (0.16 log units) above what was measured; the measured number falls inside the stated range.
By their numbers in this assay, from the lowest: compounds 3, 2 and 1 (each within the scatter of the next).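

Shrinking the six-membered non-aromatic ring to a five-membered one, at this position opposite the ring nitrogen, now has a measured result: in this assay it gives a 1.6-fold lower number from compound 2 to compound 3 (0.22 log units; within the scatter). The same exchange set against the other neighbour gives a 1.8-fold lower number from compound 1 to compound 3 (0.24 log units; within the scatter), so neither step shows a clear shift. Nothing measured here bears on the reason for these numbers. As far as these compounds go, it remains open whether a seven-membered ring, or a simple methyl group on the five-membered aromatic ring in place of the second ring, would move the number beyond the scatter.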